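The source may hold more compounds than are shown below. What is called first, only, known or untested is meant among the compounds shown, and "the series" means these compounds.

Compound 1 `Nc1ccccc1NC(=O)c1ccc(CSc2cccc(F)c2)cc1`: 18.6%
Compound 2 `Cc1ccc(SCc2ccc(C(=O)Nc3ccccc3N)cc2)cc1`: 25.1%

For the measured compounds named here, in a functional assay on SMMC-7721 cells (Homo sapiens) for inhibition, read by CCK-8 assay, with a stated time of 72 h, tested at 2 uM (a lower number here means less inhibition of growth, a higher number more inhibition of growth at the concentration tested), compound 2 gives 25.1% and cannot be told apart from its only measured neighbour (a number 6.5 percentage points higher from compound 1 to compound 2 (within the scatter)). Compound 3 `Nc1ccccc1NC(=O)c1ccc(CSCCc2ccccc2)cc1` has phenethyl in place of 4-methylphenyl on a sulfur. The one measured step, shown above, also swapped the group on that sulfur and stayed small, but no measured compound carries phenethyl, so this is only a weak guide. The estimated change (a number 1.1 percentage points lower from compound 2 to compound 3 (within the scatter)) is therefore no step beyond the scatter. Compound 3 is expected at 24%, with an estimated range from 8% to 45% in this read-out.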

Compound 3, percent growth inhibition at one concentration: 28.1%
Estimate against measurement, compound 3: 4.1 percentage points below; the range from low to high includes it.
By their numbers in this assay, from the lowest: compounds 1, 2 and 3 (each within the scatter of the next).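

In this assay, phenethyl on the sulfur gives a number 3 percentage points higher from compound 2 to compound 3 (within the scatter), and set against 3-fluorophenyl it gives a number 9.5 percentage points higher from compound 1 to compound 3 (within the scatter). Until now only rings attached directly to the sulfur had been compared, and this result shows that a ring carried on a saturated chain there cannot be told apart from either of them. Nothing measured here offers an explanation for these numbers. Still open, from the compounds shown here alone, is whether a group with no ring at all, such as an amine or a carboxylic acid, or a longer chain between the sulfur and the ring, would produce a step beyond the scatter.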